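The source may report more compounds than this note shows. Statements on the series, on what has been measured and on what is new or still open speak of the compounds shown alone.

Measured so far:
compound 1 `CCN(CC)S(=O)(=O)c1cc(OC)c(OC)cc1Cc1n[nH]c(=S)n1-c1ccc(Cl)cc1` — 3.15
compound 2 `COc1cc(Cc2n[nH]c(=S)n2-c2ccc(Cl)cc2)c(S(=O)(=O)N2CCCC2)cc1OC` — 2.11

In a physicochemical assay for lipophilicity (on this read-out higher numbers stand for higher lipophilicity and lower numbers for lower lipophilicity), compound 1 gives 3.15, the higher of the two numbers; the nearest measured neighbour is compound 2, which gives 2.11. The step between them is a number 1.04 log units lower from compound 1 to compound 2 (beyond the scatter), a large drop that comes from pyrrolidin-1-yl in place of diethylamino on a sulfonyl sulfur.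

Compound 3 `COc1cc(Cc2n[nH]c(=S)n2-c2ccc(Cl)cc2)c(S(=O)(=O)N2CCOCC2)cc1OC` has not yet been measured. It differs from compound 1 by morpholin-4-yl in place of diethylamino on a sulfonyl sulfur. Among the compounds with values here, the one measured step that bears on this change is the one from compound 1 to compound 2, where the same diethylamino group was replaced by a different ring on the same sulfonyl sulfur and the number fell by a number 1.04 log units lower from compound 1 to compound 2 (beyond the scatter). Morpholin-4-yl brings a ring as well, and in addition one hydrogen-bond acceptor, so a drop of at least that size is expected, probably somewhat larger, giving an estimated step of a number 1.45 log units lower from compound 1 to compound 3 (beyond the scatter). Compound 3 is therefore expected to show 1.7 in this assay, within a range from 1 to 2.4.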

Compound 3, partition coefficient: 2.25
For compound 3 the middle estimate is 0.55 log units below the measured one; the measured number falls inside the stated range.
By their numbers in this assay, from the lowest: compounds 2 and 3 (each within the scatter of the next); then compound 1.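

In this assay, a second ring on the sulfonyl sulfur also falls beyond the scatter from the open-chain diethylamino group, with morpholin-4-yl in place of diethylamino giving a number 0.90 log units lower from compound 1 to compound 3 (beyond the scatter). The drop seen for pyrrolidin-1-yl is therefore not a lone case: both ring compounds lie clearly under compound 1, though two rings are a small sample and neither goes against this pattern. The ring oxygen of morpholin-4-yl does not separate the two ring compounds, since the direct comparison gives a number 0.14 log units higher from compound 2 to compound 3 (within the scatter), and nothing measured here explains the gap to diethylamino or this lack of separation.

As far as these compounds go, what remains open is whether the gap follows from closing the amine into a ring or from some other difference between these groups, a question that piperidin-1-yl and a shorter open chain such as dimethylamino could help to settle. From the compounds shown here alone, it is equally open whether a ring carrying a second nitrogen, such as piperazin-1-yl, would stay level with compound 2 and compound 3.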